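The source may hold more compounds than are shown below. What is called first, only, known or untested is meant among the compounds shown, and "the series" means these compounds.

Working notes on the series. The shared core carries a phenyl on an aromatic nitrogen, and the compounds differ there and in the basic amine of the side chain. Compound 1 `COc1cc2c(Oc3ccc(NC(=O)c4nn(-c5ccccc5)c(=O)c5ccccc45)cc3F)ccnc2cc1OCCCN1CCCC1` gives 480 nM in a functional assay on NCI-H460 cells (Homo sapiens) for cytotoxicity, read by MTT assay, with a stated time of 72 h; a lower number here means a stronger inhibitor, a higher number a weaker inhibitor. Compound 2 `COc1cc2c(Oc3ccc(NC(=O)c4nn(-c5cccc(F)c5)c(=O)c5ccccc45)cc3F)ccnc2cc1OCCCN1CCCC1` gives 190 nM in this assay, and compound 3 `COc1cc2c(Oc3ccc(NC(=O)c4nn(-c5ccc(F)cc5)c(=O)c5ccccc45)cc3F)ccnc2cc1OCCCN1CCN(C)CC1` gives 91 nM in this assay. Compound 3 thus gives the lowest number of the three; the gap to compound 2 is the smaller one and the gap to compound 1 the larger, both beyond the scatter.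

For the measured compounds named here, the one step measured in one place is a 2.5-fold lower number from compound 1 to compound 2 (0.40 log units; beyond the scatter), a fluoro in place of hydrogen on an aromatic carbon of that phenyl. Going by the values given here, compound 2 and compound 3 differ in two places, so the numbers show only that compound 3 sits lower.

Compound 4 `COc1cc2c(Oc3ccc(NC(=O)c4nn(-c5ccccc5Br)c(=O)c5ccccc45)cc3F)ccnc2cc1OCCCN1CCN(C)CC1` is not yet measured. It differs from compound 3 by 2-bromophenyl in place of 4-fluorophenyl on an aromatic nitrogen. Among the compounds with values here, no measured step exchanges a halogen at one position of that phenyl for a different halogen at another, so the step from compound 1 to compound 2 bears on it only loosely, as a sign that a halogen on this phenyl moved the number modestly. For compound 4 the expected step is a 1.6-fold higher number from compound 3 to compound 4 (0.22 log units; within the scatter), a small rise within or near the scatter. Compound 4 is therefore estimated at 150 nM in this assay, with a range from 50 nM to 450 nM.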

Compound 4, half-maximal inhibitory concentration: 290 nM
For compound 4 the middle estimate is 1.9-fold (0.29 log units) below the measured one; low and high end bracket the measured number.
By their numbers in this assay, from the lowest: compound 3; then compounds 2, 4 and 1 (each within the scatter of the next, the first and the last beyond it).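

With the side chain of compound 3 held fixed, the exchange on this phenyl gives a 3.2-fold higher number from compound 3 to compound 4 (0.50 log units; beyond the scatter) in this assay, so this position also moves the number when the amine differs from that of compound 1 and compound 2. The direction is opposite to the earlier fluoro step, a 2.5-fold lower number from compound 1 to compound 2 (0.40 log units; beyond the scatter), so a halogen on this phenyl does not lower the number in every case: compound 4 goes against any such reading, although that earlier step was measured on another side chain and replaces hydrogen rather than another halogen. No measurement in hand accounts for the rise, and the data give no cause for it.

The halogen and its position change together in this step, so the compounds shown leave open how much of the rise belongs to bromine in place of fluorine and how much to the new position on the ring. They also leave open how the unsubstituted phenyl behaves with the side chain of compound 3, and whether a methoxy group or a nitrile on this phenyl would fall closer to compound 3 or to compound 4.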